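Shifting a fluorine on the benzyl group of a chalcone triazole

The source may hold more compounds than are shown below. What is called first, only, known or untested is meant among the compounds shown, and "the series" means these compounds.

Compound 3 `COc1ccc(C(=O)/C=C/c2ccc(OCc3cn(Cc4ccccc4F)nn3)cc2)cc1` gives 19% in a functional assay on MIA PaCa-2 cells (Homo sapiens) for inhibition, read by MTT assay, with a stated time of 48 h, tested at 10 uM (a lower number here means less inhibition of growth, a higher number more inhibition of growth at the concentration tested), the lowest of the three measured. Compound 1 `COc1ccc(C(=O)/C=C/c2ccc(OCc3cn(Cc4ccccc4)nn3)cc2)cc1` gives 68% and compound 2 `COc1ccc(C(=O)/C=C/c2ccc(OCc3cn(Cc4ccccc4Br)nn3)cc2)cc1` gives 50%; the steps of a number 49 percentage points lower from compound 1 to compound 3 (beyond the scatter) and a number 31 percentage points lower from compound 2 to compound 3 (beyond the scatter) are both beyond the scatter, as is a number 18 percentage points lower from compound 1 to compound 2 (beyond the scatter). Compound 4 `COc1ccc(C(=O)/C=C/c2ccc(OCc3cn(Cc4cccc(F)c4)nn3)cc2)cc1` differs from compound 3 by 3-fluorophenyl in place of 2-fluorophenyl on a saturated chain carbon bound to an aromatic nitrogen. For the measured compounds named here, no measured step moves a fluorine from one position to another, so the steps above bear only indirectly, showing that a change on this ring can shift the result considerably. The expectation is a partial recovery, a number 16 percentage points higher from compound 3 to compound 4 (beyond the scatter), with compound 4 estimated at 35%, within 10% to 65%.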

Compound 4, percent growth inhibition at one concentration: 48%
The estimate for compound 4 lay 13 percentage points below the measured number; the measured number falls inside the stated range.
By their numbers in this assay, from the lowest: compound 3; then compounds 4 and 2 (each within the scatter of the next); then compound 1.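

In this assay, moving the same fluorine gives a number 29 percentage points higher from compound 3 to compound 4 (beyond the scatter), so on this benzyl group the place of the atom matters, not only its identity. The 3-fluorophenyl group still falls short of the unsubstituted ring, with a number 20 percentage points lower from compound 1 to compound 4 (beyond the scatter), so the move recovers only part of the loss. Compound 4 also cannot be told apart from the 2-bromophenyl compound, with a number 2 percentage points lower from compound 2 to compound 4 (within the scatter) and the two within the usual scatter.

From the compounds shown here alone, whether a 3-bromophenyl group or an amine on this ring would behave like the 3-fluorophenyl group remains open. No measurement here explains why the position of the fluorine matters.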